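Swapping the ring on the piperazine nitrogen of compound 2

The source may report more compounds than this note shows. Statements on the series, on what has been measured and on what is new or still open speak of the compounds shown alone.

Of the compounds shown here, two have been tested so far in an assay on CHO cells for displacement of a labelled ligand from 5-hydroxytryptamine receptor 7 (Homo sapiens); on this read-out higher numbers stand for weaker inhibition and lower numbers for stronger inhibition. Compound 1 `COc1ccc(S(=O)(=O)NCCCN2CCN(c3cccc(OC)c3)CC2)cc1` gives 339 nM. Compound 2 `O=S(=O)(NCCCN1CCN(c2ccc(C(F)(F)F)cc2)CC1)c1ccc2ccccc2c1` gives 567 nM, which is the higher of the two numbers, though its gap to compound 1 falls within the scatter of this assay, so the two cannot be ranked against each other.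

Compound 3 `COc1cccc(N2CCN(CCCNS(=O)(=O)c3ccc4ccccc4c3)CC2)c1` keeps the core of compound 2 and changes one place: 3-methoxyphenyl in place of 4-(trifluoromethyl)phenyl on an amine nitrogen in a ring. The group that enters is the same 3-methoxyphenyl that compound 1 carries on its ring nitrogen, and compound 1 gives 339 nM in this assay. Within the data shown here, no measured pair shows this exact change, so the size of the step is uncertain. A modest move toward a lower number, near the edge of the scatter, is expected, with the step from compound 2 to compound 3 estimated as a 3.2-fold lower number from compound 2 to compound 3 (0.50 log units; beyond the scatter). Compound 3 is therefore expected to give about 180 nM, within a range from 50 nM to 650 nM.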

Compound 3, half-maximal inhibitory concentration: 223 nM
Compound 3: the middle estimate sits 1.2-fold (0.09 log units) below what was measured; the measured number falls inside the stated range.
By their numbers in this assay, from the lowest: compounds 3, 1 and 2 (each within the scatter of the next, the first and the last beyond it).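

In this assay, among these compounds, putting 3-methoxyphenyl in place of 4-(trifluoromethyl)phenyl on an amine nitrogen in a ring gives the first measured step at this position (a 2.5-fold lower number from compound 2 to compound 3 (0.41 log units; beyond the scatter)), modest but beyond the scatter, so the group held on that nitrogen does register in this assay. Naphthalen-2-yl in place of 4-methoxyphenyl on a sulfonyl sulfur gives a step within the scatter (a 1.5-fold lower number from compound 1 to compound 3 (0.18 log units; within the scatter)), so compound 1 and compound 3 cannot be ranked and this swap shows no clear effect. Nothing measured here bears on why the first step occurs.

The step swaps one whole group for another. The loss of trifluoromethyl and the gain of methoxy cannot be told apart in these data, and a plain phenyl on that nitrogen would help to separate them. As far as these compounds go, how a pyridine ring at that place, or a longer chain in the shared core, would read also remains open.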